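The source may report more compounds than this note shows. Statements on the series, on what has been measured and on what is new or still open speak of the compounds shown alone.

Measured so far in a functional assay on BCG823 cells (Homo sapiens) for antiproliferative activity, read by MTT assay, with a stated time of 48 h; on this read-out lower numbers stand for stronger inhibition and higher numbers for weaker inhibition:
compound 1 `COc1cc2oc(-c3ccccc3)cc(=O)c2c(O)c1OCCCN1CCCCC1` gives 25300 nM
compound 2 `COc1cc2oc(-c3ccccc3)cc(=O)c2c(O)c1OCCCCN1CCN(C)CC1` gives 53500 nM
compound 3 `COc1cc2oc(-c3ccccc3)cc(=O)c2c(O)c1OCCCCN1CCCCC1` gives 21900 nM

Compound 2 gives the highest number of the three. The step from compound 1 to compound 2 reads a 2.1-fold higher number from compound 1 to compound 2 (0.33 log units; beyond the scatter), and from compound 2 to compound 3 it reads a 2.4-fold lower number from compound 2 to compound 3 (0.39 log units; beyond the scatter); the step from compound 1 to compound 3 reads a 1.2-fold lower number from compound 1 to compound 3 (0.06 log units; within the scatter). All three measured steps concern the amine end of the chain.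

Compound 4 `CN1CCN(CCCCOc2c(OCc3ccccc3)cc3oc(-c4ccccc4)cc(=O)c3c2O)CC1` differs from compound 2 by phenyl in place of hydrogen on a saturated chain carbon bound to an oxygen on an aromatic ring. Among the compounds with values here, no measured step touches this part of the core, so no measured step bears on it, and the expected direction is unknown. The step from compound 2 to compound 4 is expected to be a 1.2-fold lower number from compound 2 to compound 4 (0.08 log units; within the scatter). In this assay compound 4 is therefore estimated at 45000 nM, with a range from 12000 nM to 150000 nM.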

Compound 4, half-maximal inhibitory concentration: 7200 nM
Estimate against measurement, compound 4: 6.3-fold (0.80 log units) above, and the stated range ends above it.
By their numbers in this assay, from the lowest: compound 4; then compounds 3 and 1 (each within the scatter of the next); then compound 2.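

In this assay, methoxy to benzyloxy on the core gives a 7.4-fold lower number from compound 2 to compound 4 (0.87 log units; beyond the scatter), a larger step than any seen at the amine end of the chain. Within the data shown here, this oxygen substituent, which the earlier steps left untouched, therefore moves the number further than those amine changes do, here with the 4-methylpiperazin-1-yl end in place. Nothing at hand explains the step. From the compounds shown here alone, whether it carries over to compounds with the piperidin-1-yl end stays open. Going by these compounds, how cyclohexylmethoxy, a saturated ring in place of the phenyl, would read at this oxygen also stays open.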